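Compound 3 to compound 4: methoxy for chloro

The compounds below may be only part of what the source reports. "The series", "measured", "known", "first", "only" and "open" are said of these compounds alone.

In an ADME assay on HPLF cells (Homo sapiens) for cytotoxicity, with a stated time of 24 h (on this read-out higher numbers stand for lower toxicity in this test and lower numbers for higher toxicity in this test), compound 1 `Cc1ccc(/C=C2\CCC/C(=C\c3cccc([N+](=O)[O-])c3)C2=O)cc1` reads > 400000 nM, which is a limit of the assay. Compound 2 `O=C1/C(=C/c2ccc(F)cc2)CCC/C1=C\c1ccc([N+](=O)[O-])cc1` reads > 400000 nM, also a limit. Among the measured compounds shown here, compound 3 `O=C1/C(=C/c2ccc(Cl)cc2)CCC/C1=C\c1ccc([N+](=O)[O-])cc1` gives 332000 nM, the only actual number so far.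

Compound 4 `COc1ccc(/C=C2\CCC/C(=C\c3ccc([N+](=O)[O-])cc3)C2=O)cc1` carries methoxy in place of chloro on an aromatic carbon, para to a large group: methoxy in place of chloro on an aromatic carbon. For the measured compounds named here, the one measured step on that same aromatic carbon, chloro in place of fluoro, is an at least 1.2-fold lower number from compound 2 to compound 3 (0.08 log units; that floor lies within the scatter). No step beyond the scatter is therefore expected in this assay, and no direction is favoured. The expected change is a 1.1-fold higher number from compound 3 to compound 4 (0.02 log units; within the scatter). For compound 4 the estimated value is 350000 nM, with an expected range of 180000 nM to 600000 nM, though the assay may report only a limit.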

Compound 4, half-maximal cytotoxic concentration: > 400000 nM
Compound 4: a limit, no number; the forecaster's own chance of this, stated with the estimate: 45%; at least 1.1-fold (0.05 log units) between middle value and limit.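

In this assay the change from 4-chlorophenyl to 4-methoxyphenyl gives an at least 1.2-fold higher number from compound 3 to compound 4 (0.08 log units; that floor lies within the scatter), so no step beyond the scatter can be claimed for it. Fluoro and methoxy on this aromatic carbon both end at a limit, and the step between them cannot be read. Resolution at this position is capped: the limit of > 400000 nM in this assay, at which 3 of the 4 values shown sit.

On these data alone, whether an amine or a carboxylic acid on this carbon would give a number well clear of that limit stays open. So does the effect of a longer chain, such as ethoxy, in place of methoxy.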